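Carboxy to hydroxymethyl on the chain: working notes

The source may hold more compounds than are shown below. What is called first, only, known or untested is meant among the compounds shown, and "the series" means these compounds.

- compound 1 `COc1ncc(-c2ccc3ncnc(Nc4ccc(OCCCO)nc4)c3c2)cc1NS(=O)(=O)c1ccc(F)cc1F`: 9360 nM
- compound 2 `COc1ncc(-c2ccc3ncnc(Nc4cnn(CCC(=O)O)c4)c3c2)cc1NS(C)(=O)=O`: 3840 nM

In a functional assay on A549 cells (Homo sapiens) for antiproliferative activity, read by sulforhodamine B assay, with a stated time of 72 h (a higher number here means a weaker inhibitor, a lower number a stronger inhibitor), compound 2 gives 3840 nM, the lower of the two numbers, with compound 1 higher by more than the scatter. Compound 3 `COc1ncc(-c2ccc3ncnc(Nc4cnn(CCCO)c4)c3c2)cc1NS(C)(=O)=O` carries hydroxymethyl in place of carboxy on a saturated chain carbon, two bonds along the chain from an aromatic nitrogen. Within the data shown here, the two measured compounds differ in more than one place, so no measured step guides this change. A moderate fall in the number is expected, a 4.3-fold lower number from compound 2 to compound 3 (0.63 log units; beyond the scatter), though with wide uncertainty. For compound 3 the estimated value is 900 nM, within 150 nM to 5000 nM.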

Compound 3, half-maximal inhibitory concentration: 3600 nM
The estimate for compound 3 lay 4.0-fold (0.60 log units) below the measured number, within the range that was stated.
By their numbers in this assay, from the lowest: compounds 3 and 2 (each within the scatter of the next); then compound 1.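

In this assay hydroxymethyl in place of carboxy on a saturated chain carbon, two bonds along the chain from an aromatic nitrogen, gives a 1.1-fold lower number from compound 2 to compound 3 (0.03 log units; within the scatter) and so separates the two compounds by no more than the scatter. In this pair, the carboxy group is therefore not required to reach this level of antiproliferative activity, and the 3-hydroxypropyl chain reads the same as the 2-carboxyethyl chain. No measurement shown accounts for this result. Going by these compounds, whether an amine or a longer chain at this position would read the same remains open.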